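Methyl on the Amide Nitrogen: an Expected Paw Edema Result

The source may hold more compounds than are shown below. What is called first, only, known or untested is meant among the compounds shown, and "the series" means these compounds.

Of the compounds shown here, two have so far been measured in a functional assay on the whole organism (strain Wister albino) for inhibition, with Rattus norvegicus as the target, read by paw edema, with stated times of 1 h and 2 h, at a dose of 50 mg/kg by the intraperitoneal route; on this read-out lower numbers stand for less inhibition and higher numbers for more inhibition at the one dose given (going by the name of the read-out). Compound 1 `CN1C/C(=C\c2ccc(Cl)cc2)C(=O)[C@]2(C1)[C@@H](c1ccc(Cl)cc1)CN(C)[C@@]21C(=O)Nc2ccccc21` gives 63% in this assay. Compound 2 `CN1C/C(=C\c2ccc(-c3cccs3)cc2)C(=O)[C@]2(C1)[C@@H](c1ccc(-c3cccs3)cc1)CN(C)[C@@]21C(=O)Nc2ccccc21` gives 70.7% in this assay. Compound 2 holds the higher of the two numbers, yet compound 1 lies within the usual scatter of it, so the two values cannot be told apart and neither number can be called the higher inhibition in this assay.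

Compound 3 `CN1C/C(=C\c2ccc(-c3cccs3)cc2)C(=O)[C@]2(C1)[C@@H](c1ccc(-c3cccs3)cc1)CN(C)[C@@]21C(=O)N(C)c2ccccc21` has not been measured. It differs from compound 2 in one place: methyl in place of hydrogen on an amide-type nitrogen in a ring. A hydrogen leaves and a methyl enters on an amide-type nitrogen in a five-membered non-aromatic ring within the fused system of four rings that compound 2 and compound 3 share. Going by the values given here, no measured pair in this set shows what such a change does in this assay, so no measured step can be drawn on. The expectation is therefore a step of modest size in either direction, most likely none beyond the scatter, written as a number 5.7 percentage points lower from compound 2 to compound 3 (within the scatter). Compound 3 is expected to give about 65% in this assay, with a range from 45% to 82%.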

Compound 3, a percentage reported as inhibition, in the whole organism at one dose (the size of the read-out at that dose, not a potency): 68.3%
The estimate for compound 3 lay 3.3 percentage points below the measured number; the measured number falls inside the stated range.
By their numbers in this assay, from the lowest: compounds 1, 3 and 2 (each within the scatter of the next).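

Going by these compounds alone, this is the first measured step at this position: in this assay, methyl in place of hydrogen on an amide-type nitrogen in a ring gives a number 2.4 percentage points lower from compound 2 to compound 3 (within the scatter). On the core of compound 2, then, the amide hydrogen can give way to methyl without a step that this read-out can separate from the scatter, so at this one dose the amide hydrogen is not shown to be needed for the inhibition seen. Nothing in the data shown offers a reason for this result or tells what the hydrogen or the methyl does at this place.

The compounds shown leave open whether a bigger group on this nitrogen, such as ethyl, benzyl or a chain ending in an amine or a carboxylic acid, would also stay within the scatter of compound 2 in this assay. They also leave open whether methyl on this nitrogen would give a step of similar size on the core of compound 1, and a read-out taken at one dose says nothing about potency.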